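The compounds below may be only part of what the source reports. "The series", "measured", "known", "first", "only" and "open" are said of these compounds alone.

Working notes on the series, read in an ADME assay on K562 cells (Homo sapiens) for cytotoxicity, read by MTT assay, with a stated time of 24 h; on this read-out higher numbers stand for lower toxicity in this test and lower numbers for higher toxicity in this test. Compound 3 `Cc1ccc(C(CCn2ccnc2)Oc2ccc(Cl)cc2Cl)cc1` gives 97000 nM, compound 1 `Clc1ccc(C(CCn2ccnc2)Oc2cc(Cl)cc(Cl)c2)cc1` gives 135000 nM and compound 2 `Cc1ccc(C(CCn2ccnc2)Oc2ccc(Cl)cc2)cc1` gives 171000 nM. These three numbers all lie within the scatter of one another, so compound 3 does not stand apart from the other two.

The change to compound 4 `Cc1ccc(C(CCn2ccnc2)Oc2cc(Cl)cc(Cl)c2)cc1` is 3,5-dichlorophenyl in place of 2,4-dichlorophenyl on an oxygen on a saturated carbon. The atoms stay the same and are joined differently.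

Going by the values given here, the only measured single-place step, a 1.8-fold lower number from compound 2 to compound 3 (0.25 log units; within the scatter), is a chloro in place of hydrogen on an aromatic carbon, and it stays within the scatter. Among the compounds with values here, compound 1, the one measured compound that already holds the 3,5-dichlorophenyl, gives 135000 nM, which is within the scatter of the other two values.

No step beyond the scatter is therefore expected in this assay, in either direction. The expected step is a 1.2-fold higher number from compound 3 to compound 4 (0.09 log units; within the scatter). Compound 4 is estimated at 120000 nM, with an expected range of 65000 nM to 220000 nM.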

Compound 4, half-maximal cytotoxic concentration: 98000 nM
For compound 4 the middle estimate is 1.2-fold (0.09 log units) above the measured one; the measured number falls inside the stated range.
By their numbers in this assay, from the lowest: compounds 3, 4, 1 and 2 (each within the scatter of the next).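

In this assay the exchange of 2,4-dichlorophenyl for 3,5-dichlorophenyl on an oxygen on a saturated carbon gives a 1.0-fold higher number from compound 3 to compound 4 (0.00 log units; within the scatter), so at this position the two arrangements of the same atoms are not told apart. The other two new comparisons agree: 3,5-dichlorophenyl in place of 4-chlorophenyl gives a 1.7-fold lower number from compound 2 to compound 4 (0.24 log units; within the scatter), and methyl in place of chloro on an aromatic carbon gives a 1.4-fold lower number from compound 1 to compound 4 (0.14 log units; within the scatter), which extends the flat picture to the second aryl group. No measurement offered here explains this flat picture.

All four compounds carry only chloro or methyl substituents and lie within the scatter of one another. As far as these compounds go, whether an amine or a carboxylic acid on either aryl ring, or a longer chain on the shared core, would give a step beyond the scatter remains open.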